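Methoxy to hydroxy: compound 3 to compound 4

The compounds below may be only part of what the source reports. "The series", "measured", "known", "first", "only" and "open" are said of these compounds alone.

In a functional assay on MDA-MB-468 cells (Homo sapiens) for inhibition, read by sulforhodamine B assay, with a stated time of 48 h (a higher number here means a weaker inhibitor, a lower number a stronger inhibitor), compound 1 `O=C(Nc1cccc(-n2cc(-c3ccncc3)c(-c3ccc(Cl)c(O)c3)n2)c1)Nc1cccc(C(F)(F)F)c1` gives 980 nM, compound 2 `COc1cc(-c2nn(-c3cccc(NC(=O)c4cccc(C(F)(F)F)c4)c3)cc2-c2ccncc2)ccc1Cl` gives 1320 nM and compound 3 `COc1cc(-c2nn(-c3cccc(NC(=O)Nc4ccc(Cl)c(Cl)c4)c3)cc2-c2ccncc2)ccc1Cl` gives 570 nM. Compound 3 carries the lowest of the three numbers; compound 1 sits within the usual scatter of it, compound 2 beyond it. Among the measured compounds shown here, the only single-point step measured so far, a 2.3-fold lower number from compound 2 to compound 3 (0.36 log units; beyond the scatter), concerns the group on the carbonyl carbon, not the change considered here. Compound 4 `O=C(Nc1cccc(-n2cc(-c3ccncc3)c(-c3ccc(Cl)c(O)c3)n2)c1)Nc1ccc(Cl)c(Cl)c1` differs from compound 3 by hydrogen in place of methyl on an oxygen on an aromatic ring, the 4-chloro-3-methoxyphenyl becoming 4-chloro-3-hydroxyphenyl. For the measured compounds named here, no measured pair isolates this change; compounds 1 and 3 differ in two places and their values lie within the scatter of one another. The step of a 1.1-fold higher number from compound 3 to compound 4 (0.06 log units; within the scatter) is therefore expected to stay within the scatter. Compound 4 is estimated at 650 nM, range 300 nM to 1400 nM.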

Compound 4, half-maximal inhibitory concentration: 730 nM
The estimate for compound 4 lay 1.1-fold (0.05 log units) below the measured number; measured number inside the range.
By their numbers in this assay, from the lowest: compounds 3, 4, 1 and 2 (each within the scatter of the next, the first and the last beyond it).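

In this assay, among the compounds shown here, the step of a 1.3-fold higher number from compound 3 to compound 4 (0.11 log units; within the scatter) is the first measured pair to isolate methoxy to hydroxy, and with 3,4-dichlorophenyl on the amide-type nitrogen, this oxygen carries methyl or hydrogen with no change that can be read. With hydroxy held, the step of a 1.3-fold lower number from compound 1 to compound 4 (0.13 log units; within the scatter) leaves 3,4-dichlorophenyl and 3-(trifluoromethyl)phenyl on an amide-type nitrogen unresolved as well. No measurement at hand offers an explanation for either result.

Going by these compounds, whether ethoxy or a longer chain ending in an amine on this oxygen would keep the number in this range stays open. The same holds for a carboxylic acid in place of the hydroxy.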